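Shortening the Link Between Core and Piperazine Ring

The compounds below may be only part of what the source reports. "The series", "measured", "known", "first", "only" and "open" are said of these compounds alone.

Compound 1 `Cc1cc(NCCN2CCN(C)CC2)nc2ccc(NC(=O)c3ccc(Cl)c(Cl)c3)cc12` is one of two compounds tested in a functional assay on SK-BR-3 cells (Homo sapiens) for antiproliferative activity, read by MTT assay, with a stated time of 72 h; on this read-out lower numbers stand for stronger inhibition and higher numbers for weaker inhibition. In this assay compound 1 gives 2690 nM, the lowest of the two numbers. Compound 2 `CCN1CCN(c2cc(C)c3cc(NC(=O)c4ccc(F)cc4)ccc3n2)CC1` gives 19800 nM in this assay, a higher number that lies beyond the usual scatter. Compound 3 `Cc1cc(N2CCN(C)CC2)nc2ccc(NC(=O)c3ccc(Cl)c(Cl)c3)cc12` has not yet been measured. It differs from compound 1 in a single place: 4-methylpiperazin-1-yl in place of (2-(4-methylpiperazin-1-yl)ethyl)amino on an aromatic carbon. Going by the values given here, no measured pair shows this exact change on its own, so its effect is not known from the data. Compound 2 also carries a 4-methylpiperazin-1-yl group directly on the core, though it differs from compound 3 elsewhere as well, and its weaker result gives some hint. For compound 3 the step of a 2.2-fold higher number from compound 1 to compound 3 (0.35 log units; beyond the scatter) is expected to be a moderate loss. Compound 3 is therefore estimated at 6000 nM, with a likely range from 2000 nM to 20000 nM.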

Compound 3, half-maximal inhibitory concentration: 6320 nM
The estimate for compound 3 lay 1.1-fold (0.02 log units) below the measured number, and the stated range covers the measured number.
By their numbers in this assay, from the lowest: compound 1; then compound 3; then compound 2.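

In this assay, setting the 4-methylpiperazin-1-yl group directly on the aromatic carbon, in place of (2-(4-methylpiperazin-1-yl)ethyl)amino, gives a 2.3-fold higher number from compound 1 to compound 3 (0.37 log units; beyond the scatter). Going by these compounds alone, this is the first direct reading of this change on its own: on this core, the linking chain and its hydrogen-bond donor can go at a modest cost, and the activity is not abolished. Nothing shown accounts for this loss.

Here the length of the link and the nitrogen attached to the core change together, so their separate contributions remain open. An ether chain such as 2-(4-methylpiperazin-1-yl)ethoxy, with oxygen in place of that nitrogen, or a longer chain such as (3-(4-methylpiperazin-1-yl)propyl)amino would help tell them apart.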